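The source may hold more compounds than are shown below. What is called first, only, known or untested is meant among the compounds shown, and "the series" means these compounds.

In a functional assay on DU-145 cells (Homo sapiens) for inhibition, read by trypan blue exclusion, with a stated time of 96 h (a lower number here means a stronger inhibitor of growth, a higher number a weaker inhibitor of growth), compound 1 `O=C(/C(=C\c1ccc(F)cc1F)Sc1ccc(Br)cc1)c1ccc(Br)cc1` gives 1000 nM, a measured number. Compound 2 `Cc1ccc(S/C(=C/c2ccc(N(C)C)cc2)C(=O)c2ccc(Br)cc2)cc1` gives > 100000 nM in this assay. That entry is a limit of the assay and not a number, so the position of compound 2 is known only as a limit.

Compound 3 `Cc1ccc(S/C(=C/c2ccc(F)cc2F)C(=O)c2ccc(Br)cc2)cc1` has not yet been measured. Its structure departs from that of compound 2 at one place: 2,4-difluorophenyl in place of 4-(dimethylamino)phenyl on a double-bonded chain carbon bound to a double-bonded chain carbon. In words, 2,4-difluorophenyl stands in place of 4-(dimethylamino)phenyl on a double-bonded chain carbon bound to a double-bonded chain carbon.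

The entering group is not new to this small set, since compound 1 also carries 2,4-difluorophenyl and gives 1000 nM. Going by the values given here, with only two measured compounds and no measured step, that value is a rough guide, and it is the main ground for the expectation here. A large move towards stronger inhibition of growth is expected in this assay, and the estimate for it is an at least 66-fold lower number from compound 2 to compound 3 (1.82 log units; beyond the scatter). For compound 3 the expected value is 1500 nM, with an estimated range from 300 nM to 8000 nM.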

Compound 3, concentration for 50% growth inhibition: > 100000 nM
Compound 3: a limit, no number; the forecaster's own chance of this, stated with the estimate: 10%; at least 66-fold (1.82 log units) between middle value and limit.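

In this assay compound 3 gives > 100000 nM, which is a limit of the assay and not a number. Placing methyl in place of bromo on an aromatic carbon, with 2,4-difluorophenyl kept, gives an at least 100-fold higher number from compound 1 to compound 3 (2.00 log units; beyond the scatter), so 2,4-difluorophenyl alone does not secure the growth inhibition seen with compound 1, and this one change on an aromatic carbon is enough to lose it. The step from compound 2 to compound 3 cannot be read, because both compounds stand at the same limit and neither has a number: the limit of > 100000 nM in this assay, at which 2 of the 3 values shown sit.

The compounds shown leave open whether 4-(dimethylamino)phenyl would also give a measurable value with bromo on that aromatic carbon, so the effect of exchanging it for 2,4-difluorophenyl remains unknown. They also leave open whether bromo is specifically required there, or whether a chloro group or a methoxy group on the same aromatic carbon would restore growth inhibition in this assay.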